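The source may report more compounds than this note shows. Statements on the series, on what has been measured and on what is new or still open speak of the compounds shown alone.

Series notes. Compound 1, `CCc1c(-c2ccccc2)nn(CCCCCCCCC(=O)O)c1-c1ccccc1`, compound 2, `O=C(O)CCCCCCCCn1cc(-c2ccccc2)cn1`, and compound 3, `CC(C)(C)OC(=O)COCCCCCCn1nc(-c2ccccc2)c(-c2ccccc2)c1-c1ccccc1`, share a pyrazole nitrogen carrying a long saturated chain, and all three have been run in a functional assay for inhibition, with Homo sapiens as the target; on this read-out lower numbers stand for stronger inhibition and higher numbers for weaker inhibition. For compound 1 the result is a limit of the assay, > 79000 nM. For compound 2 the result is likewise a limit, > 105000 nM. For compound 3 the result is again a limit, > 62000 nM, so compound 3 stands where every value shown stands: at a limit, with no number to rank it against compound 1 or compound 2 (the limit of > 105000 nM in this assay, at which 1 of the 3 values shown sits, (the limit of > 62000 nM in this assay, at which 1 of the 3 values shown sits), (the limit of > 79000 nM in this assay, at which 1 of the 3 values shown sits)).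

The next compound, compound 4, `c1ccc(-c2nn(CCCCCCCCc3nnn[nH]3)c(-c3ccccc3)c2-c2ccccc2)cc1`, differs from compound 3 in one place: 2-(1H-tetrazol-5-yl)ethyl in place of (tert-butoxycarbonyl)methoxy on a saturated chain carbon, six bonds along the chain from an aromatic nitrogen.

Among the measured compounds shown here, no step between measured compounds is available to size this change. Compound 1 carries an acid at the chain end and still sits at a limit, so no gain beyond the scatter is expected in this assay from compound 3 to compound 4, and a further limit is the likeliest outcome. The estimate for compound 4 in this assay is 100000 nM, within 30000 nM to 300000 nM, which means an expected step that the limit leaves unreadable from compound 3 to compound 4.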

Compound 4, half-maximal inhibitory concentration: 1040 nM
The estimate for compound 4 lay 96-fold (1.98 log units) above the measured number; the measured number lies below the stated range.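

In this assay, 2-(1H-tetrazol-5-yl)ethyl in place of (tert-butoxycarbonyl)methoxy on a saturated chain carbon, six bonds along the chain from an aromatic nitrogen, gives an at least 59-fold lower number from compound 3 to compound 4 (1.77 log units; beyond the scatter). Among the compounds shown here, this position is therefore not silent: a change in this one place yields the first value that is a number and not a limit. The step gives only a lower bound on the size of the change, because the value of compound 3 is a limit: the limit of > 62000 nM in this assay, at which 1 of the 4 values shown sits.

The pair leaves open whether the gain goes with the 1H-tetrazol-5-yl ring itself or with the loss of (tert-butoxycarbonyl)methoxy. Also open, going by these compounds, is how a sulfonamide or an amide at the same chain end, or a longer chain ending in the same ring, would read in this assay.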